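Cyclohexyl on the ring nitrogen of the semicarbazone series

This account rests on a few compounds, and the source may have more. Where it says the series, first, only, none or still open, it means among the compounds named here.

Measured so far in an ADME assay on BHK-21 cells (Mesocricetus auratus) for cytotoxicity, read by MTT assay; on this read-out lower numbers stand for higher toxicity in this test and higher numbers for lower toxicity in this test:
compound 1 `CC(=O)c1ccc2[nH]c(-c3ccc(Cl)cc3)nc2c1`: > 100000 nM
compound 2 `C/C(=N\NC(N)=O)c1ccc2[nH]c(-c3ccc(Cl)cc3)nc2c1`: > 100000 nM

In this assay compound 1 gives only a limit of the assay. Compound 2 likewise gives only a limit. Compound 2 thus sits at the limit of > 100000 nM in this assay, at which 2 of the 2 values shown sit. Among the compounds with values here, the one measured step, a step that the two limits leave unreadable from compound 1 to compound 2, cannot be read between two limits, so no measured step bears readably on the next change. Compound 3 `C/C(=N\NC(N)=O)c1ccc2c(c1)nc(-c1ccc(Cl)cc1)n2C1CCCCC1` carries cyclohexyl in place of hydrogen on an aromatic nitrogen. With nothing to point elsewhere, compound 3 is expected to stay near the limit, estimated at 100000 nM (range 30000 nM to 300000 nM), an expected step of a number no higher from compound 2 to compound 3 (the limit leaves the size open) within the scatter.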

Compound 3, half-maximal cytotoxic concentration: > 100000 nM
Compound 3 ended at the assay's limit (the forecaster's own chance of this, stated with the estimate: 60%); the middle value lies on the limit itself.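

Within the data shown here, compound 2 and compound 3 each give only a limit, so no step between them can be read: the limit of > 100000 nM in this assay, at which 3 of the 3 values shown sit.

In this assay the compounds shown leave open at what concentration, if any, compound 1, compound 2 or compound 3 would become cytotoxic.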